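Arylsulfonyl substituent change from compound 3 to compound 4

The source may hold more compounds than are shown below. What is called first, only, known or untested is meant among the compounds shown, and "the series" means these compounds.

Among the compounds with values here, compound 3 `Cc1c(CC(=O)O)c2ccsc2n1S(=O)(=O)c1ccc(C(F)(F)F)cc1` gives 1130 nM in an assay on HEK293 cells for displacement of a labelled ligand from prostaglandin D2 receptor 2 (Homo sapiens) (a lower number here means a stronger inhibitor, a higher number a weaker inhibitor), the lowest of the three numbers so far; compound 2 `Cc1c(CC(=O)O)c2ccsc2n1S(=O)(=O)c1ccc(F)cc1` gives 1630 nM, and compound 1 `CS(=O)(=O)c1ccc(S(=O)(=O)n2cc(CC(=O)O)c3ccsc32)cc1` gives 4000 nM. Within the data shown here, the one step recorded between neighbours, a 1.4-fold lower number from compound 2 to compound 3 (0.16 log units; within the scatter), lies within the scatter. Compound 4 `Cc1c(CC(=O)O)c2ccsc2n1S(=O)(=O)c1ccc(S(=O)(=O)N2CCOCC2)cc1` carries (morpholin-4-yl)sulfonyl in place of trifluoromethyl on an aromatic carbon. Among the measured compounds shown here, no measured step bears directly on this change; the only other sulfonyl-bearing analogue, compound 1, also differs from compound 3 elsewhere on the shared core, so its higher number cannot be assigned to the sulfonyl group alone. The expectation for compound 4 is therefore a modest rise, a 2.2-fold higher number from compound 3 to compound 4 (0.34 log units; beyond the scatter), with wide uncertainty. Compound 4 is estimated at 2500 nM, range 800 nM to 8000 nM.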

Compound 4, half-maximal inhibitory concentration: 230 nM
Estimate against measurement, compound 4: 11-fold (1.04 log units) above; measured number below the stated range.
By their numbers in this assay, from the lowest: compound 4; then compounds 3 and 2 (each within the scatter of the next); then compound 1.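

At the aromatic carbon para to a large group, (morpholin-4-yl)sulfonyl gives a step in this assay beyond the scatter: a 4.9-fold lower number from compound 3 to compound 4 (0.69 log units; beyond the scatter) and a 7.1-fold lower number from compound 2 to compound 4 (0.85 log units; beyond the scatter) on the same core. Within the data shown here, the step from fluoro to trifluoromethyl had stayed within the scatter, so only this change shows that the number responds to the substituent here. No measured evidence accounts for the drop.

Open, from the compounds shown here alone, is whether the sulfonyl link or the morpholine ring carries the drop. A piperidine ring or dimethylamino group on the sulfonyl would separate these.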